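Trifluoromethyl in Place of Hydrogen on the Benzyl Ring

The compounds below may be only part of what the source reports. "The series", "measured", "known", "first", "only" and "open" are said of these compounds alone.

Measured compounds:
Compound 1, `Cc1cc(S(=O)(=O)/N=C(\N)n2nccc2-c2ccccc2)c(SCc2ccccc2Cl)cc1Cl`, gives 0.226 h.
Compound 2, `Cc1cc(S(=O)(=O)/N=C(\N)n2nccc2-c2ccccc2)c(SCc2ccccc2C)cc1Cl`, gives 0.0802 h.
Compound 3, `Cc1cc(S(=O)(=O)/N=C(\N)n2nccc2-c2ccccc2)c(SCc2ccccc2)cc1Cl`, gives 0.0772 h.

All three were run in an ADME assay on microsomes from liver (Homo sapiens) for metabolic stability, read by LC-MS, using NADPH, tested at 5 uM; a lower number here means that the compound disappears faster, a higher number that the compound lasts longer. Compound 3 has the lowest of the three numbers, but compound 2 lies within the scatter of it (a 1.0-fold lower number from compound 2 to compound 3 (0.02 log units; within the scatter)), so the two are not told apart. Among the compounds with values here, compound 1 stands apart from both (a 2.9-fold lower number from compound 1 to compound 3 (0.47 log units; beyond the scatter) and a 2.8-fold lower number from compound 1 to compound 2 (0.45 log units; beyond the scatter)), and these two steps are the only ones that change the same carbon of the benzyl ring.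

Compound 4, `Cc1cc(S(=O)(=O)/N=C(\N)n2nccc2-c2ccccc2)c(SCc2ccccc2C(F)(F)F)cc1Cl`, differs from compound 3 by trifluoromethyl in place of hydrogen on an aromatic carbon. Within the data shown here, no measured step covers a trifluoromethyl at that carbon. The chloro there brought a modest higher number, the methyl none beyond the scatter; a trifluoromethyl is a larger group at the same place, without a direct precedent in these data. A modest rise is therefore expected, a 1.9-fold higher number from compound 3 to compound 4 (0.29 log units; within the scatter), with the chance of a smaller or no change kept open. Compound 4 is estimated at 0.15 h, within a range of 0.07 h to 0.35 h.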

Compound 4, half-life: 0.15 h
Compound 4: the middle estimate sits on the measured number at the digits printed, within the range that was stated.
By their numbers in this assay, from the lowest: compounds 3, 2, 4 and 1 (each within the scatter of the next, the first and the last beyond it).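

In this assay, within the data shown here, trifluoromethyl at this carbon of the benzyl ring is the first group that cannot be placed on either side of the gap seen among the earlier compounds, since it lies within the scatter of hydrogen (a 1.9-fold higher number from compound 3 to compound 4 (0.29 log units; within the scatter)), of methyl (a 1.9-fold higher number from compound 2 to compound 4 (0.27 log units; within the scatter)) and of chloro (a 1.5-fold lower number from compound 1 to compound 4 (0.18 log units; within the scatter)). The position had separated chloro from methyl and hydrogen, but compound 4 bridges that gap and does not join either side. Nothing available here accounts for how these groups read at this carbon.

Going by these compounds, whether a fluoro, methoxy or nitrile group at the same carbon would read with compound 1 or with compounds 2 and 3 remains open. So does the reading of a trifluoromethyl on another carbon of the benzyl ring.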